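Swapping a Thiophene for an Alkyne on a Weak Compound

The source may report more compounds than this note shows. Statements on the series, on what has been measured and on what is new or still open speak of the compounds shown alone.

Compounds 1, 2 and 3 share one core and differ only in the group on a single aromatic carbon. Compound 1 `COc1ncnc2c1c(-c1cccs1)cn2[C@@H]1O[C@H](CO)[C@@H](O)[C@H]1O` carries methoxy there, and in a functional assay on HCT-116 cells (Homo sapiens), read by MTT assay, with a stated time of 72 h (a lower number here means a stronger inhibitor, a higher number a weaker inhibitor), compound 1 gives 80 nM. Compound 2 `CNc1ncnc2c1c(-c1cccs1)cn2[C@@H]1O[C@H](CO)[C@@H](O)[C@H]1O` carries methylamino in place of methoxy, and in this assay compound 2 reaches only a limit of the assay, > 20000 nM. Compound 3 `CSc1ncnc2c1c(-c1cccs1)cn2[C@@H]1O[C@H](CO)[C@@H](O)[C@H]1O` carries methylsulfanyl in place of methoxy, and compound 3 likewise reaches only a limit of the assay, > 20000 nM. The two changes away from methoxy are therefore large losses: an at least 250-fold higher number from compound 1 to compound 2 (2.39 log units; beyond the scatter) and an at least 250-fold higher number from compound 1 to compound 3 (2.39 log units; beyond the scatter). Between the two weak compounds the step is a step that the two limits leave unreadable from compound 2 to compound 3, since both sit at the limit of > 20000 nM in this assay, at which 2 of the 3 values shown sit.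

Compound 4 `C#Cc1cn([C@@H]2O[C@H](CO)[C@@H](O)[C@H]2O)c2ncnc(SC)c12` keeps the methylsulfanyl of compound 3 and changes a different place: ethynyl in place of thiophen-2-yl on an aromatic carbon. For the measured compounds named here, none of the measured steps touches this position; all of them concern the group that replaced methoxy, so no measured step shows which way this change should move the number. Because compound 3 stands at a limit, > 20000 nM, the size of the step to compound 4 cannot be read either. Compound 4 is expected to give about 15000 nM, within 3000 nM to 20000 nM. The expected step is an at least 1.3-fold lower number from compound 3 to compound 4 (0.12 log units; that floor lies within the scatter).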

Compound 4, half-maximal inhibitory concentration: 30 nM
The estimate for compound 4 lay 500-fold (2.70 log units) above the measured number; the measured number lies below the stated range.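

In this assay, the carbon bearing thiophen-2-yl proves to be a position that matters greatly: ethynyl in place of thiophen-2-yl gives an at least 660-fold lower number from compound 3 to compound 4 (2.82 log units; beyond the scatter). For the compounds shown here, all the earlier steps concerned the group that replaced methoxy, and they left methylsulfanyl looking like a dead end, whereas compound 4 carries that same methylsulfanyl and is a strong inhibitor, so the weakness of compound 3 is not set by methylsulfanyl alone but also depends on the group at this second place. Going by these compounds, the step is only a floor and its true size stays unknown, because compound 3 sits at a limit of the assay rather than at a number: the limit of > 20000 nM in this assay, at which 2 of the 4 values shown sit.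

This change is seen in a single pair, so the compounds shown cannot tell whether ethynyl would have the same effect with methoxy or methylamino on the shared core. They also leave open how far the result depends on the triple bond itself, which a nitrile, a longer alkyne such as propynyl, or a plain ethyl chain on the same carbon would help to show.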